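Ester chain extension on the acetoxy quinone, compound 3 to 4

A few compounds are considered here, and "the series" means these few. Any claim that something is new, unique, unknown or untested is made for them only; others in the source may bear on it.

Compound 3 `COc1ccc(O)c2c1C(=O)C=C([C@H](CC=C(C)C)OC(C)=O)C2=O` gives 10200 nM in a functional assay on Hep 3B2 cells (Homo sapiens) for cytotoxicity, read by MTT assay, with a stated time of 48 h (on this read-out lower numbers stand for stronger inhibition and higher numbers for weaker inhibition), the second highest of the three numbers measured. Its nearest neighbour is compound 2 `COc1ccc(O)c2c1C(=O)C=C(CCC=C(C)C)C2=O`, which gives 15800 nM; the step of a 1.5-fold lower number from compound 2 to compound 3 (0.19 log units; within the scatter) is within the scatter. Furthest off is compound 1 `CC(C)=CC[C@H](OC(=O)C=C(C)C)C1=CC(=O)c2c(O)ccc(O)c2C1=O`, which gives 4090 nM, a number beyond the scatter lower than that of compound 3.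

Compound 4 `COc1ccc(O)c2c1C(=O)C=C([C@H](CC=C(C)C)OC(=O)C=C(C)C)C2=O` differs from compound 3 in one place: 2-methylprop-1-en-1-yl in place of methyl on a carbonyl carbon. Going by the values given here, no measured step covers this change alone. Among the compounds with values here, the only measured step, from compound 2 to compound 3, concerns a different change and does not bear on it. Compound 1 carries the same ((2-methylprop-1-en-1-yl)carbonyl)oxy group as compound 4 but on a core that differs from that of compound 3 in a second place, so its value cannot be read as a step; it shows only that this ester on another core gave a lower number than compound 3.

For compound 4 the expected step is a 1.5-fold lower number from compound 3 to compound 4 (0.16 log units; within the scatter), a modest lowering that may not clear the scatter. Compound 4 is therefore estimated at 7000 nM, with a range from 3000 nM to 16000 nM.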

Compound 4, half-maximal inhibitory concentration: 11800 nM
Compound 4: middle estimate off by 1.7-fold (0.23 log units), on the low side; the range from low to high includes it.
By their numbers in this assay, from the lowest: compound 1; then compounds 3, 4 and 2 (each within the scatter of the next).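

In this assay the change of methyl to 2-methylprop-1-en-1-yl on the carbonyl carbon gives a 1.2-fold higher number from compound 3 to compound 4 (0.06 log units; within the scatter) and so does not separate the two esters. Against the chain without any ester the result is a 1.3-fold lower number from compound 2 to compound 4 (0.13 log units; within the scatter) so, like the acetoxy group, this larger ester does not separate from hydrogen on that chain carbon. The step that clears the scatter lies elsewhere: methyl in place of hydrogen on an oxygen on an aromatic ring gives a 2.9-fold higher number from compound 1 to compound 4 (0.46 log units; beyond the scatter) with the ester held constant.

No measurement shown gives a reason for any of these steps. Open, from the compounds shown here alone, is whether an amine, a carboxylic acid or a longer chain in place of 2-methylprop-1-en-1-yl on the carbonyl carbon would give a step beyond the scatter.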